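This account rests on a few compounds, and the source may have more. Where it says the series, first, only, none or still open, it means among the compounds named here.

Compound 1 `COc1cccc(/C=C/C(=O)c2ccc(OC)c3c2OC(C)(C)C=C3)c1` is the starting point of this account. In a functional assay on SW-620 cells (Homo sapiens) for antiproliferative activity, read by MTT assay, with a stated time of 24 h (a lower number here means a stronger inhibitor, a higher number a weaker inhibitor), compound 1 gives only a limit, > 10000 nM. Among the measured compounds shown here, its neighbour compound 2 `COc1ccc(/C=C/C(=O)c2ccc(OC)c3c2OC(C)(C)C=C3)c(F)c1` carries a 2-fluoro-4-methoxyphenyl in place of the 3-methoxyphenyl, and in this assay compound 2 gives 6570 nM; this is the only plain number among the three measured compounds, and the step of an at least 1.5-fold lower number from compound 1 to compound 2 (0.18 log units; that floor lies within the scatter) rests on a limit at one end. Compound 3 `COc1ccc(C(=O)/C=C/c2ccco2)c2c1C=CC(C)(C)O2` carries a furan-2-yl on the same chain carbon. In this assay compound 3 again gives only a limit, > 10000 nM. Accordingly the step that the two limits leave unreadable from compound 1 to compound 3 cannot be read, while an at least 1.5-fold higher number from compound 2 to compound 3 (0.18 log units; that floor lies within the scatter) is again bounded by a limit. For the measured compounds named here, both limits sit at the same place, (the limit of > 10000 nM in this assay, at which 2 of the 3 values shown sit), so compound 1 stands at that edge together with compound 3, and no measured step shows a change clearly beyond the scatter.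

Compound 4 `COc1ccc(C(=O)/C=C/c2ccccc2Cl)c2c1C=CC(C)(C)O2` differs from compound 1 by 2-chlorophenyl in place of 3-methoxyphenyl on a double-bonded chain carbon bound to a double-bonded chain carbon. The nearest measured precedent is the aryl swap from compound 1 to compound 2, whose size the limit hides. The expected step is therefore an at least 1.2-fold lower number from compound 1 to compound 4 (0.09 log units; that floor lies within the scatter), a modest move toward a readable number that may well stay at the limit. Compound 4 is expected to give about 8000 nM in this assay, within 2500 nM to 30000 nM.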

Compound 4, half-maximal inhibitory concentration: > 10000 nM
Compound 4: no number, only a limit (the forecaster's own chance of this, stated with the estimate: 50%); middle value at least 1.2-fold (0.09 log units) away from the limit.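

Putting 2-chlorophenyl on this chain carbon leaves compound 4 at the limit of this assay, so a chlorine-bearing ring with no hydrogen-bond acceptor gives no plain number here either: the limit of > 10000 nM in this assay, at which 3 of the 4 values shown sit. The only step with any size is an at least 1.5-fold higher number from compound 2 to compound 4 (0.18 log units; that floor lies within the scatter), and it rests on a limit at one end, so compound 2 is not shown to stand clearly apart from compound 4. The steps to compound 4 from compound 1 and from compound 3 have limits at both ends and cannot be read.

Going by these compounds, how far past the limit compound 1, compound 3 and compound 4 lie stays open, and so does whether the 2-fluoro-4-methoxyphenyl of compound 2 really makes a difference. Also open, on these data alone, is what a phenyl ring carrying an amine or a carboxylic acid would give on this chain carbon.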